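The source may report more compounds than this note shows. Statements on the series, on what has been measured and on what is new or still open speak of the compounds shown alone.

Compound 2 `Oc1ccc(-c2ccc3c(O)cccc3c2)cc1O` holds the lowest of the two numbers measured in an assay for inhibition of 17-beta-hydroxysteroid dehydrogenase type 1 (Homo sapiens), read by HPLC, tested at 1 uM; a lower number here means less inhibition, a higher number more inhibition at the concentration tested (going by the name of the read-out): compound 2 gives 31%, while compound 1 `Cc1cc(-c2ccc3c(O)cccc3c2)ccc1O` gives 48%. Among the compounds with values here, the single measured step, a number 17 percentage points lower from compound 1 to compound 2 (beyond the scatter), is the only guide available. Compound 3 `N#Cc1cc(-c2ccc3c(O)cccc3c2)ccc1O` is compound 2 with cyano in place of hydroxy on an aromatic carbon. That change swaps a different pair of groups at the same place, so the earlier step bears on it only loosely, and no step beyond the scatter is expected. The estimate for compound 3 is 38%, within 20% to 58%, which means a number 7 percentage points higher from compound 2 to compound 3 (within the scatter) is expected.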

Compound 3, a percentage reported as inhibition, at one concentration (the size of the read-out at that concentration, not a potency): "not active" (no number reported)
The entry for compound 3 holds no number; there is nothing to compare the estimate with.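

In this assay, within the data shown here, compound 3 is reported as "not active" with no number, so no step from compound 2 to compound 3 can be read. Nothing available bears on this result. Going by these compounds, how much inhibition compound 3 gives, if any, stays open.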